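Aryl Fluorination in a Glutamate Receptor Modulator Series

This account rests on a few compounds, and the source may have more. Where it says the series, first, only, none or still open, it means among the compounds named here.

Measured compounds:
compound 1 `Cc1c(OCCCCOc2cccc(C(=O)O)c2)ccc(C(=O)CC2CCCC2)c1O` — 451 nM
compound 2 `Cc1c(OCCCCOc2cccc(C(=O)O)c2)ccc(C(=O)CC(C)C)c1O` — 222 nM

Of the compounds shown here, two sharing one core have been measured in an assay on HEK293 cells for positive allosteric modulation of metabotropic glutamate receptor 2 (Rattus norvegicus), read by thallium flux, with a stated time of 2.5 min; on this read-out lower numbers stand for an effect already at smaller amounts and higher numbers for an effect only at larger amounts of compound. Compound 1 gives 451 nM, the highest of the two numbers, while compound 2 gives 222 nM. Among the compounds with values here, the only step between them, a 2.0-fold lower number from compound 1 to compound 2 (0.31 log units; beyond the scatter), lies on the ketone-bearing side of the core and is the sole measured step in this set.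

Compound 3 `Cc1c(OCCCCOc2ccc(F)c(C(=O)O)c2)ccc(C(=O)CC2CCCC2)c1O` is not yet measured. It differs from compound 1 at the other end of the molecule: fluoro in place of hydrogen on an aromatic carbon. Within the data shown here, no measured step in this set touches that aromatic ring, so the step from compound 1 to compound 2 offers no direct guidance here; it shows only that a change at one end of the core moved the number modestly. With nothing bearing on the acid-bearing ring, the step is expected to fall within the scatter. Compound 3 is accordingly estimated at 450 nM, within a range from 180 nM to 1100 nM. This estimate corresponds to a 1.0-fold lower number from compound 1 to compound 3 (0.00 log units; within the scatter).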

Compound 3, half-maximal effective concentration: 699 nM
For compound 3 the middle estimate is 1.6-fold (0.19 log units) below the measured one; low and high end bracket the measured number.
By their numbers in this assay, from the lowest: compound 2; then compounds 1 and 3 (each within the scatter of the next).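

In this assay, within the data shown here, placing fluoro on the acid-bearing ring, on the aromatic carbon ortho to the carboxy group and para to a large group, gives a 1.5-fold higher number from compound 1 to compound 3 (0.19 log units; within the scatter) as the only step at this end of the molecule. It shows that, on the cyclopentyl ketone of compound 1, the 3-carboxyphenyl end can become 3-carboxy-4-fluorophenyl while the number stays within the usual scatter of repeated measurements, so this one carbon accepts a fluorine atom in place of hydrogen without a readable shift. No measurement at hand bears on the reason for this outcome.

On these data alone, whether a larger group on the same carbon, such as chloro or methoxy, would also stay within the scatter of compound 1 remains open, as does the effect of fluoro on the other carbons of this ring. As far as these compounds go, it is equally open whether the same fluoro would leave the number of compound 2, with its isopropyl in place of cyclopentyl, within the scatter.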